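Moving an ether link on the outer phenyl ring

The compounds below may be only part of what the source reports. "The series", "measured", "known", "first", "only" and "open" are said of these compounds alone.

Measured so far:
compound 1 `CCOc1ccccc1-c1ccc(-c2nc3cnccc3c(N[C@H](CC)C(N)=O)c2C#N)cc1`: 3
compound 2 `CCOc1ccccc1-c1ccc(-c2nc3cnccc3c(NC(COC)C(N)=O)c2C#N)cc1`: 2.8
compound 3 `CCOc1ccccc1-c1ccc(-c2nc3cnccc3c(N[C@H](CC)C(=O)NS(=O)(=O)C3CC3)c2C#N)cc1`: 2.3

In a physicochemical assay for lipophilicity, read by HPLC, at pH 7.5 (a lower number here means a more polar compound, a higher number a more lipophilic compound), compound 1 gives the highest of the three numbers. Compound 2 is a number 0.20 log units lower from compound 1 to compound 2 (within the scatter), and compound 3 is a number 0.70 log units lower from compound 1 to compound 3 (beyond the scatter). Compound 4 `CC[C@@H](Nc1c(C#N)c(-c2ccc(-c3ccccc3COC)cc2)nc2cnccc12)C(N)=O` differs from compound 1 in one place: methoxymethyl in place of ethoxy on an aromatic carbon. The measured steps, a number 0.20 log units lower from compound 1 to compound 2 (within the scatter) and a number 0.50 log units lower from compound 2 to compound 3 (beyond the scatter) among them, all change the group on the nitrogen on the aromatic ring, so none speaks directly to a change on the aromatic carbon. Going by the values given here, with no measured step bearing on this change, compound 4 is expected to stay close to compound 1, giving a number 0.10 log units lower from compound 1 to compound 4 (within the scatter). The estimate for compound 4 in this assay is 2.9, between 2.5 and 3.3.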

Compound 4, distribution coefficient: 2.6
Beside the measured number, compound 4's estimate is 0.30 log units above it; measured number inside the range.
By their numbers in this assay, from the lowest: compounds 3, 4, 2 and 1 (each within the scatter of the next, the first and the last beyond it).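

With ethoxy replaced by methoxymethyl on the aromatic carbon, ortho to a large group, this assay gives a number 0.40 log units lower from compound 1 to compound 4 (beyond the scatter). The earlier steps shown here all changed the group on the nitrogen on the aromatic ring, whereas this one shows that the outer ring also registers a change, even though the two groups have the same atoms, joined differently. Nothing available accounts for this difference.

The compounds shown leave open how a longer chain such as 2-methoxyethyl, or an amine such as dimethylaminomethyl, would read at this position. They also leave open whether the same step would appear with the groups on the nitrogen in compound 2 and compound 3.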